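Dimethylamino to diethylamino on the basic side chain

This account rests on a few compounds, and the source may have more. Where it says the series, first, only, none or still open, it means among the compounds named here.

Measured compounds:
Compound 1 `CN(C)CCn1c(N)c(-c2nc3ccccc3[nH]2)c2nc(C#N)c(C#N)nc21` — in a functional assay on Raji cells (Homo sapiens) for antiproliferative activity, read by MTT assay, with a stated time of 48 h (a higher number here means a weaker inhibitor, a lower number a stronger inhibitor), compound 1 gives 8320 nM.
Compound 2 `CCN(CC)CCn1c(N)c(-c2nc3ccccc3[nH]2)c2nc(C#N)c(C#N)nc21` — in this assay compound 2 gives 8950 nM.
Compound 3 `CN(C)CCCn1c(N)c(-c2nc3ccccc3n2C)c2nc(C#N)c(C#N)nc21` — in this assay compound 3 gives 940 nM.

From compound 1 to compound 2 the change is diethylamino in place of dimethylamino on a saturated chain carbon, two bonds along the chain from an aromatic nitrogen. The step it made, a 1.1-fold higher number from compound 1 to compound 2 (0.03 log units; within the scatter), is within the scatter, so nothing can be said about an order between these two. Compound 3 gives the lowest number of the three, and the gaps to compound 1 and to compound 2 are both beyond the scatter; how its core differs from the core of compound 1 is not broken down here.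

Compound 4 `CCN(CC)CCCn1c(N)c(-c2nc3ccccc3n2C)c2nc(C#N)c(C#N)nc21` is not yet measured. It differs from compound 3 by diethylamino in place of dimethylamino on a saturated chain carbon, three bonds along the chain from an aromatic nitrogen. This is the same kind of change as from compound 1 to compound 2, but the place is not the same: there the amine sits two bonds along the chain from the aromatic nitrogen, here three bonds along the chain. Because a 1.1-fold higher number from compound 1 to compound 2 (0.03 log units; within the scatter) was within the scatter, the step from compound 3 to compound 4 is expected to be of similar size, a 1.1-fold higher number from compound 3 to compound 4 (0.05 log units; within the scatter). Compound 4 is therefore estimated at 1050 nM, likely between 500 nM and 2200 nM.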

Compound 4, half-maximal inhibitory concentration: 2220 nM
For compound 4 the middle estimate is 2.1-fold (0.33 log units) below the measured one, outside the stated range (above it).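

In this assay, the change from dimethylamino to diethylamino on the 3-(dimethylamino)propyl chain gives a 2.4-fold higher number from compound 3 to compound 4 (0.37 log units; beyond the scatter), so compound 4 reads as a modest step away from compound 3. Set beside the earlier pair, this step does not separate from the first one, so the change can be treated as carrying across the two cores so far: the same change on two cores in this assay, a 1.1-fold higher number (0.03 log units; within the scatter) from compound 1 to compound 2 and a 2.4-fold higher number (0.37 log units; beyond the scatter) from compound 3 to compound 4, 2.2-fold (0.34 log units) apart, within the scatter of two such steps

This does not show that the step is identical on both cores, nor that it depends on the core, and two pairs that differ in both chain and core cannot say which of those would set its size.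

Still open, as far as these compounds go, is whether the 3-(diethylamino)propyl chain on the core of compound 1 would give a step like that of the 2-(diethylamino)ethyl chain, which would separate the effect of chain from that of core. Also open, from the compounds shown here alone, is how a cyclic amine such as pyrrolidine or morpholine, or a longer butyl chain, would read.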